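This account rests on a few compounds, and the source may have more. Where it says the series, first, only, none or still open, it means among the compounds named here.

Compound 3 `O=[N+]([O-])c1ccc(Oc2ccc(/C=N/NC(=S)Nc3ccc(Br)cc3)cc2)cc1` gives 5.68 in a physicochemical assay for lipophilicity, in phosphate buffer, measured as octanol-water partition, with a stated time of 24 h; on this read-out lower numbers stand for lower lipophilicity and higher numbers for higher lipophilicity. Its two measured companions sit within the usual scatter of it: compound 1 `S=C(N/N=C/c1ccc(Oc2ccc(Br)cc2)cc1)Nc1ccccc1` gives 5.62, and compound 2 `S=C(N/N=C/c1ccc(Oc2ccc(Cl)cc2)cc1)Nc1ccccc1` gives 5.52. Among the measured compounds shown here, the one step among them, chloro in place of bromo, gave a number 0.10 log units lower from compound 1 to compound 2 (within the scatter). Compound 4 `O=[N+]([O-])c1ccc(Oc2ccc(/C=N/NC(=S)Nc3ccccc3)cc2)cc1` differs from compound 3 by hydrogen in place of bromo on an aromatic carbon. For the measured compounds named here, no measured step removes a halogen entirely, so the expectation rests loosely on the chloro-for-bromo step, which points downward and stayed small; losing the bromo altogether is expected to lower this assay somewhat more, as a number 0.53 log units lower from compound 3 to compound 4 (beyond the scatter). Compound 4 is therefore estimated at 5.15, with a range from 4.65 to 5.65.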

Compound 4, partition coefficient: 4.95
Compound 4: middle estimate off by 0.20 log units, on the high side, within the range that was stated.
By their numbers in this assay, from the lowest: compound 4; then compounds 2, 1 and 3 (each within the scatter of the next).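

In this assay, the change from 4-bromophenyl to phenyl gave a number 0.73 log units lower from compound 3 to compound 4 (beyond the scatter), so taking this bromo off moved the number beyond the scatter. Nitro in place of chloro gave a number 0.57 log units lower from compound 2 to compound 4 (beyond the scatter) and nitro in place of bromo gave a number 0.67 log units lower from compound 1 to compound 4 (beyond the scatter), both also beyond the scatter, whereas chloro in place of bromo had stayed within it. No accompanying measurement accounts for these steps. As far as these compounds go, whether losing the bromo gives a similar step when a halogen stands where the nitro is remains open, as does what an amine or a methoxy group would give at either place.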